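From 4-nitrophenyl to 2-nitrophenyl in a three-compound series

The source may report more compounds than this note shows. Statements on the series, on what has been measured and on what is new or still open speak of the compounds shown alone.

In an ADME assay on RAW264.7 cells (Mus musculus) for inhibition, read by MTT assay, with a stated time of 72 h, tested at 50 uM (a lower number here means less inhibition of growth, a higher number more inhibition of growth at the concentration tested), compound 1 `O=C(N/N=C(/N=N/c1ccccc1Cl)c1ccccc1)c1cc(O)c(O)c(O)c1` gives 24.5%, compound 2 `O=C(N/N=C(/N=N/c1ccc(F)cc1)c1ccccc1)c1cc(O)c(O)c(O)c1` gives 11.9%, and compound 3 `O=C(N/N=C(/N=N/c1ccc([N+](=O)[O-])cc1)c1ccccc1)c1cc(O)c(O)c(O)c1` gives 11.1%. Compound 3 therefore sits level with compound 2 at the low end of these numbers, and clearly under compound 1.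

The next structure, compound 4 `O=C(N/N=C(/N=N/c1ccccc1[N+](=O)[O-])c1ccccc1)c1cc(O)c(O)c(O)c1`, differs from compound 3 in one place: 2-nitrophenyl in place of 4-nitrophenyl on a double-bonded nitrogen. Within the data shown here, three measured steps bear on this change. The first, a number 0.8 percentage points lower from compound 2 to compound 3 (within the scatter), stays within the scatter and offers little guidance. The other two, a number 12.6 percentage points lower from compound 1 to compound 2 (beyond the scatter) and a number 13.4 percentage points lower from compound 1 to compound 3 (beyond the scatter), are modest and of similar size. Read in reverse, they hint that compound 4 could move back toward compound 1. However, chloro is not nitro, and no measured pair shows the nitro group itself changing place, so only part of that size is carried over. The expected change is upward and smaller than those two steps, and it may not clear the scatter: a number 6.9 percentage points higher from compound 3 to compound 4 (within the scatter). For compound 4 the estimated value is 18%, with an expected range from 9% to 30%.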

Compound 4, percent growth inhibition at one concentration: 2.11%
Beside the measured number, compound 4's estimate is 15.9 percentage points above it; the measured number lies below the stated range.
By their numbers in this assay, from the lowest: compounds 4, 3 and 2 (each within the scatter of the next); then compound 1.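

In this assay, moving the nitro group to give 2-nitrophenyl in place of 4-nitrophenyl on the double-bonded nitrogen produces a number 9 percentage points lower from compound 3 to compound 4 (within the scatter), so these two arrangements of the same atoms cannot be told apart here. The comparison with the 4-fluorophenyl group reads the same way, with a number 9.8 percentage points lower from compound 2 to compound 4 (within the scatter). The clear step is a number 22.4 percentage points lower from compound 1 to compound 4 (beyond the scatter), where nitro replaces chloro on an aromatic carbon, so the higher number of compound 1 goes with 2-chlorophenyl and is not shared by 2-nitrophenyl, which shows that the substituent matters here and not only its numbered place on the phenyl ring. Nothing measured here accounts for any of these steps.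

Still open, on these data alone, is whether a 2-aminophenyl or 2-methoxyphenyl group on the same nitrogen would stay level with compound 4 or approach compound 1, which would show how particular the 2-chlorophenyl result is. As far as these compounds go, it is equally open whether 4-chlorophenyl would keep the number of compound 1 or fall level with compound 2 and compound 3, a comparison that would separate the chloro group from its place on the ring.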